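From Methyl to Chlorine on the Phenyl Arm

This account rests on a few compounds, and the source may have more. Where it says the series, first, only, none or still open, it means among the compounds named here.

Measured compounds:
Compound 1: `Cn1c(=O)c(=O)n(C2CCCC2)c2nc(N/N=C/c3ccccc3)ncc21`
Compound 2: `Cn1c(=O)c(=O)n(C2CCCC2)c2nc(N/N=C/c3ccc(O)cc3)ncc21`
Compound 3: `Cc1cccc(/C=N/Nc2ncc3c(n2)n(C2CCCC2)c(=O)c(=O)n3C)c1`
Not yet measured:
Compound 4: `Cn1c(=O)c(=O)n(C2CCCC2)c2nc(N/N=C/c3ccc(Cl)cc3)ncc21`

All three measured compounds share one core and differ only in the phenyl ring that sits on the carbon with a double bond to nitrogen. In a functional assay on PC-3 cells (Homo sapiens) for antiproliferative activity, read by MTT assay (on this read-out lower numbers stand for stronger inhibition and higher numbers for weaker inhibition), compound 1 gives 48200 nM. Compound 3 gives 53600 nM. For compound 2 the assay reports only a limit, > 100000 nM, which is the limit of > 100000 nM in this assay, at which 1 of the 3 values shown sits, and not a number. Among the two real numbers compound 3 stands highest, but its nearest neighbour compound 1 is separated from it by a 1.1-fold higher number from compound 1 to compound 3 (0.05 log units; within the scatter), so the two cannot be told apart. The move from compound 1 to compound 2 shows an at least 2.0-fold higher number from compound 1 to compound 2 (0.31 log units; beyond the scatter), and from compound 2 to compound 3 there is an at least 1.8-fold lower number from compound 2 to compound 3 (0.27 log units; that floor lies within the scatter).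

Compound 4 differs from compound 3 by 4-chlorophenyl in place of 3-methylphenyl on a carbon with a double bond to nitrogen. Among the measured compounds shown here, no measured step places a chlorine on this ring. The methyl step gave no change worth noting, while the hydroxy step made the number higher. The expectation for compound 4 is therefore a number close to that of compound 3, with some risk of a higher value: compound 4 is estimated at 55000 nM, in a range from 25000 nM to 120000 nM. This estimate means an expected step of a 1.0-fold higher number from compound 3 to compound 4 (0.01 log units; within the scatter).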

Compound 4, half-maximal inhibitory concentration: 8420 nM
Compound 4: middle estimate off by 6.5-fold (0.82 log units), on the high side, outside the stated range (below it).
By their numbers in this assay, from the lowest: compound 4; then compounds 1 and 3 (each within the scatter of the next). At a limit, above all of these: compound 2.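

In this assay, among the compounds shown here, chlorine is the first change on this phenyl ring to give a lower number beyond the scatter: a 5.7-fold lower number from compound 1 to compound 4 (0.76 log units; beyond the scatter), and a 6.4-fold lower number from compound 3 to compound 4 (0.80 log units; beyond the scatter), whereas the methyl of compound 3 gave only a 1.1-fold higher number from compound 1 to compound 3 (0.05 log units; within the scatter). A single atom placed on an aromatic carbon of the ring can therefore shift the result in either direction, since hydroxy gave a higher number than hydrogen while chloro gave a lower one, and the contrast between those two groups is the widest seen so far: an at least 11-fold lower number from compound 2 to compound 4 (1.07 log units; beyond the scatter). That last step is a floor and not an exact size, as compound 2 is known only through a limit of the assay: the limit of > 100000 nM in this assay, at which 1 of the 4 values shown sits.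

The step from compound 3 changes both the group and its place on the ring, so 3-chlorophenyl and 4-methylphenyl would be needed to tell whether the chlorine itself or its place matters more. Whether the lower number is particular to chlorine also stays open, as bromine, fluorine, a nitrile and an amine on the same ring are absent from the compounds shown.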